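Sulfonyl aryl swap in a hydroxy-amide series

The compounds below may be only part of what the source reports. "The series", "measured", "known", "first", "only" and "open" are said of these compounds alone.

Measured compounds:
compound 1, `CC(O)(C(=O)Nc1ccc(S(=O)(=O)c2cccc(F)c2)cc1)C(F)(F)F`, 3400 nM
compound 2, `CC(O)(C(=O)Nc1ccc(C#N)c(Sc2ccccc2)c1)C(F)(F)F`, 8300 nM

In a functional assay (Cavia porcellus) with sulfonylurea receptors; K-ATP channels (Homo sapiens) as the target (a lower number here means a stronger inhibitor, a higher number a weaker inhibitor), compound 1 gives 3400 nM, the lower of the two numbers recorded. Compound 2 gives 8300 nM in this assay, and the gap between the two numbers lies beyond the scatter, so compound 1 reads as the stronger inhibitor of the pair. The two compounds differ in more than one place, so no single step can be read from them.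

Compound 3, `CC(O)(C(=O)Nc1ccc(S(=O)(=O)c2ccccc2O)cc1)C(F)(F)F`, is not yet measured. It differs from compound 1 in one place: 2-hydroxyphenyl in place of 3-fluorophenyl on a sulfonyl sulfur. Going by the values given here, no measured pair in this set shows what such a swap does, so the account can only state an expectation. The step from compound 1 to compound 3 is estimated at a 1.3-fold higher number from compound 1 to compound 3 (0.12 log units; within the scatter), that is, within the scatter, with a slight lean toward a higher number. On that basis compound 3 is expected to give about 4500 nM in this assay, within a range from 1500 nM to 14000 nM.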

Compound 3, half-maximal inhibitory concentration: 3090 nM
The estimate for compound 3 lay 1.5-fold (0.16 log units) above the measured number; measured number inside the range.
By their numbers in this assay, from the lowest: compounds 3 and 1 (each within the scatter of the next); then compound 2.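

In this assay, placing 2-hydroxyphenyl in place of 3-fluorophenyl on a sulfonyl sulfur amounts to a 1.1-fold lower number from compound 1 to compound 3 (0.04 log units; within the scatter), so the two compounds read alike. Going by these compounds alone, this is the first view of this position, and it shows that an exchange of aryl groups there can leave the number within the scatter, even though the entering group counts 1 hydrogen-bond donor and 1 hydrogen-bond acceptor and the leaving group counts neither. No measurement is available that would explain this outcome.

Within the data shown here, the single pair cannot separate the loss of fluorine from the arrival of hydroxyl, since the two groups also sit at different places on their rings, and steps to compound 2 cannot be read, as it differs from both other compounds in more than one place. From the compounds shown here alone, whether the number would stay the same with an unsubstituted phenyl, or with an amine or a carboxylic acid on the ring, remains open.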